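Aryl swap on the carbonyl carbon: compound 3 to compound 4

The compounds below may be only part of what the source reports. "The series", "measured", "known", "first", "only" and "open" are said of these compounds alone.

Three compounds have numbers in a functional assay on HOP-62 cells (Homo sapiens) for inhibition, read by sulforhodamine B assay, with a stated time of 48 h; a lower number here means that less compound is tolerated, a higher number that more compound is tolerated. Compound 1 `COc1cc(-c2cc(/C=C/C(=O)c3ccc(Cl)c(Cl)c3)[nH]n2)cc(OC)c1OC` gives 42600 nM, compound 2 `COc1ccc(-c2cc(/C=C/C(=O)c3cc(OC)c(OC)c(OC)c3)[nH]n2)cc1OC` gives 8850 nM, and compound 3 `COc1ccc(C(=O)/C=C/c2cc(-c3cc(OC)c(OC)c(OC)c3)n[nH]2)cc1` gives 8070 nM. Compound 3 stands at the low end of the three, with compound 2 inside the usual scatter of it and compound 1 beyond it. Compound 4 `COc1cc(-c2cc(/C=C/C(=O)c3ccc(F)c(F)c3)[nH]n2)cc(OC)c1OC` differs from compound 3 by 3,4-difluorophenyl in place of 4-methoxyphenyl on a carbonyl carbon. Among the measured compounds shown here, the one measured step that bears on this change is a 5.3-fold lower number from compound 1 to compound 3 (0.72 log units; beyond the scatter); the change to compound 4 runs partway back toward the aryl group of compound 1. A step upward is therefore expected, a 2.5-fold higher number from compound 3 to compound 4 (0.39 log units; beyond the scatter), though not the full size of that earlier step. Compound 4 is accordingly estimated at 20000 nM, with a range from 8000 nM to 50000 nM.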

Compound 4, concentration lethal to 50% of the cells: > 100000 nM
Compound 4 gave a limit, no number; the forecaster's own chance of this, stated with the estimate: 10%; middle value at least 5.0-fold (0.69 log units) away from the limit.
By their numbers in this assay, from the lowest: compounds 3 and 2 (each within the scatter of the next); then compound 1. At a limit, above all of these: compound 4.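

In this assay compound 4 gives a limit, not a number: the limit of > 100000 nM in this assay, at which 1 of the 4 values shown sits. Among the compounds shown here, the aryl group on the carbonyl carbon therefore moves the read-out further than the earlier compounds showed, with an at least 12-fold higher number from compound 3 to compound 4 (1.09 log units; beyond the scatter). The two halogens are also not interchangeable at this position, with an at least 2.3-fold higher number from compound 1 to compound 4 (0.37 log units; beyond the scatter), so 3,4-dichlorophenyl and 3,4-difluorophenyl do not read alike.

Going by these compounds, the true size of both steps stays open, since each rests on a limit. Also open, on these data alone, is how a 4-aminophenyl or 4-carboxyphenyl group would read on the same carbonyl carbon.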